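Swapping Fluoro for Methyl on the Aromatic Ring

The source may hold more compounds than are shown below. What is called first, only, known or untested is meant among the compounds shown, and "the series" means these compounds.

In a physicochemical assay for lipophilicity (a lower number here means a more polar compound, a higher number a more lipophilic compound), compound 2 `Fc1ccccc1C1=NC(c2ccccc2)CO1` gives 3.51. That is the middle of three numbers, and it lies within the usual scatter of the other two. The nearest neighbour is compound 3 `Fc1cccc(Cl)c1C1=NC(c2ccccc2)CO1` at 3.45, and the furthest is compound 1 `COc1cccc(C2=NC(c3ccccc3)CO2)c1` at 3.77.

The next compound to consider is compound 4 `Cc1ccccc1C1=NC(c2ccccc2)CO1`, which keeps the core of compound 2 and changes one group: methyl in place of fluoro on an aromatic carbon. In other words, this is methyl in place of fluoro on an aromatic carbon.

For the measured compounds named here, only one measured step between closely related compounds is available. It is a number 0.06 log units lower from compound 2 to compound 3 (within the scatter), a chloro in place of hydrogen on an aromatic carbon. This is a different exchange, so it offers only a loose guide, but it does suggest that a single small substitution on this core need not move this assay much. Going by the values given here, no measured pair here involves a methyl, so the direction remains tentative.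

A small rise that stays within the scatter is expected, and the estimated change is a number 0.29 log units higher from compound 2 to compound 4 (within the scatter). For compound 4 the expected value is 3.8, with an estimated range of 3.5 to 4.1.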

Compound 4, partition coefficient: 3.68
Beside the measured number, compound 4's estimate is 0.12 log units above it; low and high end bracket the measured number.
By their numbers in this assay, from the lowest: compounds 3, 2, 4 and 1 (each within the scatter of the next, the first and the last beyond it).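

For the compounds shown here, this is the first measured step at this position, on an aromatic carbon ortho to a large group. Methyl in place of fluoro gives a number 0.17 log units higher from compound 2 to compound 4 (within the scatter) in this assay, so on this evidence the exchange cannot be told apart from the spread of repeated measurements. Together with the earlier a number 0.06 log units lower from compound 2 to compound 3 (within the scatter), it means that both single changes measured from compound 2 stay within the scatter, although one swaps one group for another and the other adds a chloro in place of hydrogen; nothing measured here explains the size of either step.

Going by these compounds, both steps are small, and each group has been tested only once, so it remains open whether any change at this position can move the number beyond the scatter, for example an amine, a carboxylic acid or a longer chain in place of the methyl. Also open, on these data alone, is whether the step from fluoro to methyl would stay the same on a core carrying a further group, such as the chloro of compound 3.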